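The compounds below may be only part of what the source reports. "The series", "measured", "known", "first", "only" and "open" are said of these compounds alone.

Measured in a functional assay on MDA-MB-231 cells (Homo sapiens) for antiproliferative activity, with a stated time of 4 days; on this read-out higher numbers stand for weaker inhibition and lower numbers for stronger inhibition:
- compound 1 `COc1ccc(-c2[nH]c3cc(OC)ccc3c2C=O)cc1`: 35 nM
- compound 2 `COc1ccc(-c2[nH]c3cc(F)ccc3c2C=O)cc1`: 59 nM
- compound 3 `COc1ccc(-c2[nH]c3ccc(F)cc3c2C=O)cc1`: 540 nM

Compound 1, at 35 nM, lies within the scatter of compound 2, at 59 nM. Compound 3, at 540 nM, has a clearly higher number than both. Among the measured compounds shown here, compound 3 differs from compound 1 in more than one place, so it offers no single step for comparison.

Compound 4 `COc1ccc(-c2[nH]c3cc(Cl)ccc3c2C=O)cc1` carries chloro in place of methoxy on an aromatic carbon of the core of compound 1: chloro in place of methoxy on an aromatic carbon.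

For the measured compounds named here, the one measured step that bears on this change is a 1.7-fold higher number from compound 1 to compound 2 (0.23 log units; within the scatter), where fluoro replaces methoxy on the same carbon. Going by the values given here, no measured compound yet carries chloro, so this comparison is indirect. In this assay, a small upward shift or none beyond the scatter is therefore expected. The expected step is a 1.7-fold higher number from compound 1 to compound 4 (0.23 log units; within the scatter).

For compound 4 the estimate is 60 nM, with an expected range from 25 nM to 150 nM.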

Compound 4, half-maximal inhibitory concentration: 27 nM
For compound 4 the middle estimate is 2.2-fold (0.35 log units) above the measured one; low and high end bracket the measured number.
By their numbers in this assay, from the lowest: compounds 4, 1 and 2 (each within the scatter of the next, the first and the last beyond it); then compound 3.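

In this assay, a 1.3-fold lower number from compound 1 to compound 4 (0.11 log units; within the scatter) shows that chloro, with no hydrogen-bond acceptor counted for it, can stand on this carbon in place of methoxy without a change beyond the scatter. Among the compounds shown here, the halogen exchange on the same carbon gives a 2.2-fold lower number from compound 2 to compound 4 (0.34 log units; beyond the scatter) and is the first step at this position to pass the scatter, though only modestly, while methoxy remains within the scatter of both halogens. No measured evidence accounts for this difference between chloro and fluoro.

As far as these compounds go, it remains open whether a group such as an amine, a hydroxyl or a longer alkoxy chain on this carbon would stay in the same range. Also open, from the compounds shown here alone, is how chloro would read on the carbon that carries fluoro in compound 3 .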